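The source may hold more compounds than are shown below. What is called first, only, known or untested is meant among the compounds shown, and "the series" means these compounds.

Of the compounds shown here, two have been measured so far. Compound 1 `COc1ccc(Cn2c(CCc3ccccc3)nnc2[C@H](NC(=O)C(C)(C)N)c2c[nH]c3ccccc23)c(OC)c1` and compound 2 `COc1ccc(-n2c(CCc3ccccc3)nnc2[C@H](NC(=O)c2ccccn2)c2c[nH]c3ccccc23)c(OC)c1` share most of their structure and differ in the amide attached to the indolyl methine and in the way the 2,4-dimethoxyphenyl group is joined to the shared core. In an in vitro assay on LLC-PK1 cells for displacement of a labelled ligand from growth hormone secretagogue receptor type 1 (Homo sapiens) (a lower number here means a stronger inhibitor, a higher number a weaker inhibitor), compound 1 gives 60 nM. In this assay compound 2 gives 33 nM, the lower of the two numbers, but its gap to compound 1 lies within the scatter of repeated measurements, so no order between the two can be read from these values.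

Compound 3 `O=C(N[C@H](c1c[nH]c2ccccc12)c1nnc(CCc2ccccc2)n1-c1ccccc1)c1ccccn1` has not yet been measured in this assay. It differs from compound 2 in one place: phenyl in place of 2,4-dimethoxyphenyl on an aromatic nitrogen. The change removes the two methoxy groups and leaves the rest of compound 2 intact. Within the data shown here, no measured pair shows the effect of this change, so the expectation rests on compound 2 alone. The estimated step is a 1.5-fold higher number from compound 2 to compound 3 (0.18 log units; within the scatter), expected to stay close to the scatter rather than beyond it. Compound 3 is expected to give about 50 nM, within a range from 15 nM to 170 nM.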

Compound 3, half-maximal inhibitory concentration: 105 nM
Compound 3: middle estimate off by 2.1-fold (0.32 log units), on the low side, within the range that was stated.
By their numbers in this assay, from the lowest: compounds 2, 1 and 3 (each within the scatter of the next, the first and the last beyond it).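

In this assay, among these compounds, replacing 2,4-dimethoxyphenyl with phenyl on the aromatic nitrogen gives a 3.2-fold higher number from compound 2 to compound 3 (0.50 log units; beyond the scatter), and this is the first single change here whose effect can be read. The aromatic ring stays in place and only the two methoxy groups leave, so the modest loss seen in this one pair goes with those two groups, and the earlier comparison, which differed in two places and stayed within the scatter, could not show this. No measurement available here bears on why the number rises with this change.

The compounds shown leave open whether both methoxy groups contribute to the step or whether one alone would account for it, which a phenyl carrying a single methoxy group could separate, and whether other groups on this ring, such as a hydroxyl, a fluorine or an amine, would match the 2,4-dimethoxyphenyl. They also leave open whether the step would hold with the amide of compound 1 in place of the amide shared by compound 2 and compound 3.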